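A few compounds are considered here, and "the series" means these few. Any claim that something is new, unique, unknown or untested is made for them only; others in the source may bear on it.

Of the compounds shown here, three have so far been tested in a functional assay on SW480 cells (Homo sapiens) for antiproliferative activity, read by MTT assay, with a stated time of 72 h; a higher number here means a weaker inhibitor, a lower number a stronger inhibitor. Compound 1 `O=c1c(Cl)c(CSC(=S)N2CCOCC2)oc2ccccc12` gives 1800 nM, the second highest of the three numbers. Compound 3 `O=c1c(CSC(=S)N2CCCCC2)coc2cc(Cl)ccc12` gives 790 nM, and compound 2 `O=c1c(SC(=S)N2CCCCC2)coc2ccccc12` gives 16300 nM, so compound 1 sits nearer to compound 3 than to compound 2, with both gaps beyond the usual scatter. Compound 4 `O=c1c(Cl)c(CSC(=S)N2CCCCC2)oc2ccccc12` has not yet been measured; it differs from compound 1 in one place: piperidin-1-yl in place of morpholin-4-yl on a thiocarbonyl carbon. For the measured compounds named here, no measured pair differs by this change alone, so no measured step tells its size. Compounds 2 and 3 both carry piperidin-1-yl but differ elsewhere too, and their numbers fall on either side of compound 1. The step of a 1.4-fold lower number from compound 1 to compound 4 (0.14 log units; within the scatter) is expected to be modest, most likely within the scatter. Compound 4 is estimated at 1300 nM, between 450 nM and 4000 nM.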

Compound 4, half-maximal inhibitory concentration: 690 nM
The estimate for compound 4 lay 1.9-fold (0.28 log units) above the measured number; measured number inside the range.
By their numbers in this assay, from the lowest: compounds 4 and 3 (each within the scatter of the next); then compound 1; then compound 2.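

In this assay, the step of a 2.6-fold lower number from compound 1 to compound 4 (0.42 log units; beyond the scatter) gives the first direct measure of this change on a thiocarbonyl carbon, with the rest of the molecule held the same. The two rings have the same number of heavy atoms, with the oxygen of morpholin-4-yl replaced by a carbon in piperidin-1-yl, yet the step lies beyond the scatter. No measurement shown explains why. Still open, on these data alone, is how a piperazin-1-yl ring or an open-chain diethylamino group would behave at this place, and whether the same swap gives a similar step on other cores.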